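Three Hydroxyphenyl Rings on a Pyridine-Free Named Core

The source may report more compounds than this note shows. Statements on the series, on what has been measured and on what is new or still open speak of the compounds shown alone.

Compound 1 `Oc1ccc(-c2cc(-c3ccc(O)cc3)nc(-c3ccc(O)cc3)c2)cc1` carries a 4-hydroxyphenyl group at each of the three positions of its shared core, and in a functional assay on HCT-15 cells (Homo sapiens) for cytotoxicity, read by CCK-8 assay, with a stated time of 4 days (on this read-out lower numbers stand for stronger inhibition and higher numbers for weaker inhibition), compound 1 gives 5120 nM. Compound 2 `Oc1cccc(-c2cc(-c3cccc(O)c3)nc(-c3ccccc3O)c2)c1` instead bears two 3-hydroxyphenyl groups and one 2-hydroxyphenyl group; in this assay compound 2 reaches only the limit of > 50000 nM, so no number is known for it. Compound 3 `Oc1ccc(-c2cc(-c3cccc(O)c3)cc(-c3cccc(O)c3)n2)cc1` keeps the two 3-hydroxyphenyl groups but has a 4-hydroxyphenyl group in the third place, and in this assay compound 3 gives 3090 nM. Among the compounds with values here, the single change gives an at least 16-fold lower number from compound 2 to compound 3 (1.20 log units; beyond the scatter); that the starting point is a limit of > 50000 nM in this assay, at which 1 of the 3 values shown sits, means only a bound on this step is known. Among the two numbers reported, compound 3 holds the lowest, with compound 1 beside it within the scatter, so no order between these two can be read. Compound 4 `Oc1ccc(-c2cc(-c3cccc(O)c3)cc(-c3ccc(O)cc3)n2)cc1` differs from compound 3 by 4-hydroxyphenyl in place of 3-hydroxyphenyl on an aromatic carbon. Compound 1 and compound 3, which differ in exactly this kind of swap at another position, sit within the scatter of each other, so no step beyond the scatter is expected in this assay; compound 4 is estimated at 3500 nM, between 1500 nM and 8000 nM, a step of a 1.1-fold higher number from compound 3 to compound 4 (0.05 log units; within the scatter).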

Compound 4, half-maximal inhibitory concentration: > 50000 nM
Compound 4: a limit, no number; the forecaster's own chance of this, stated with the estimate: 3%; middle value at least 14-fold (1.15 log units) from the limit.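

Swapping 3-hydroxyphenyl for 4-hydroxyphenyl next to the ring nitrogen, two groups with the same atom counts, gives an at least 16-fold higher number from compound 3 to compound 4 (1.20 log units; beyond the scatter) in this assay, so the outcome at this position turns on where the hydroxyl sits on the phenyl ring, which the earlier compounds had not shown for this swap. The reverse kind of swap, 3-hydroxyphenyl in place of 4-hydroxyphenyl at another place on the shared core, gives an at least 9.7-fold higher number from compound 1 to compound 4 (0.98 log units; beyond the scatter), so among these compounds the same kind of exchange cannot be read apart from what the rest of the core carries, and compound 4 stands clearly apart from both of its neighbours. Both steps are bounds rather than sizes: the limit of > 50000 nM in this assay, at which 2 of the 4 values shown sit.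

From the compounds shown here alone, how far compound 4 lies beyond its limit stays unknown, and with it the true size of both steps. Also open, going by these compounds, is whether a hydroxyl is needed on the phenyl ring next to the ring nitrogen at all, or whether a methoxy group or an amine in its place would give a number in this assay.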